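Amide-nitrogen variation: cell inhibition notes

This account rests on a few compounds, and the source may have more. Where it says the series, first, only, none or still open, it means among the compounds named here.

Measured so far:
compound 1, `COc1cccc(OC)c1C(=O)Nc1c[nH]nc1C(=O)NC1CCN(Cc2ccccc2)C1`: 38000 nM
compound 2, `COc1cccc(OC)c1C(=O)Nc1c[nH]nc1C(=O)NC1CC1`: > 50000 nM

In an ADME assay on MRC5 cells (Homo sapiens) for inhibition, with a stated time of 72 h (a higher number here means that more compound is needed for the effect, a lower number that less compound is needed), compound 1 gives 38000 nM. For compound 2 only a limit is recorded in this assay, namely > 50000 nM, so no number is known for it. Compound 2 thus sits at the limit of > 50000 nM in this assay, at which 1 of the 2 values shown sits. Going by the values given here, what the two values show is that neither compound is strongly active here; no step between them is available, so nothing more can be said about the gap between compound 1 and compound 2 than the two values themselves.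

Compound 3, `COc1cccc(OC)c1C(=O)Nc1c[nH]nc1C(=O)Nc1ccncc1`, is the next one to be measured in this assay. Its difference from compound 2 is pyridin-4-yl in place of cyclopropyl on an amide-type nitrogen. With compound 2 known only as a limit, the expected step of an at least 1.1-fold lower number from compound 2 to compound 3 (0.04 log units; that floor lies within the scatter) is taken as none beyond the scatter. Compound 3 is therefore expected to give about 45000 nM, within 15000 nM to 150000 nM, with a fair chance that again only a limit is reported.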

Compound 3, half-maximal effective concentration: > 50000 nM
Compound 3: no number, only a limit; the forecaster's own chance of this, stated with the estimate: 55%; at least 1.1-fold (0.04 log units) between middle value and limit.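

Compound 2 and compound 3 both sit at a limit in this assay, so no step can be read between them: the limit of > 50000 nM in this assay, at which 2 of the 3 values shown sit.

The compounds shown leave open whether pyridin-4-yl in place of cyclopropyl on an amide-type nitrogen changes the half-maximal effective concentration at all.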